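A smaller side chain on the shared core

The source may hold more compounds than are shown below. What is called first, only, known or untested is meant among the compounds shown, and "the series" means these compounds.

Measured in a functional assay on HepG2 cells (Homo sapiens) for inhibition, read by MTT assay, with a stated time of 48 h; a higher number here means a weaker inhibitor, a lower number a stronger inhibitor:
- compound 1 `COc1ccc(N(C)c2nc(C)nc3ccccc23)cc1C(=O)OCCC[Se]C#N`: 340 nM
- compound 2 `COc1ccc(N(C)c2nc(C)nc3ccccc23)cc1C(=O)NCC[Se]C#N`: 179 nM
- compound 3 `COc1ccc(N(C)c2nc(C)nc3ccccc23)cc1C(=O)OCCCC[Se]C#N`: 975 nM

Of these three, compound 3 has the highest number, 975 nM, which makes it the weakest inhibitor so far. The next structure, compound 4 `COc1ccc(N(C)c2nc(C)nc3ccccc23)cc1OCC[Se]C#N`, swaps its side chain for a smaller one with no carbonyl: a group of 6 heavy atoms (3 carbon, 1 nitrogen, 1 oxygen, 1 selenium; no ring) in place of a group of 10 heavy atoms (6 carbon, 1 nitrogen, 2 oxygen, 1 selenium; no ring), on an aromatic carbon. The change sits on an aromatic carbon, ortho to a methoxy group.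

Going by the values given here, two measured steps bear on this. They are a 2.9-fold higher number from compound 1 to compound 3 (0.46 log units; beyond the scatter) and a 5.4-fold higher number from compound 2 to compound 3 (0.74 log units; beyond the scatter), and in each the compound with the smaller side chain has the lower number. The remaining step, a 1.9-fold lower number from compound 1 to compound 2 (0.28 log units; within the scatter), does not separate compound 1 from compound 2. Among the compounds with values here, no measured step removes the carbonyl, so that part of the change is untested, and the range must stay wide.

A modest move towards stronger inhibition in this assay is therefore expected, estimated as a 3.3-fold lower number from compound 3 to compound 4 (0.51 log units; beyond the scatter). For compound 4 the estimated value is 300 nM, with an expected range of 100 nM to 900 nM.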

Compound 4, half-maximal inhibitory concentration: 14 nM
Beside the measured number, compound 4's estimate is 21-fold (1.33 log units) above it, outside the stated range (below it).
By their numbers in this assay, from the lowest: compound 4; then compounds 2 and 1 (each within the scatter of the next); then compound 3.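

In this assay, the group of 6 heavy atoms on the aromatic carbon gives a 70-fold lower number from compound 3 to compound 4 (1.84 log units; beyond the scatter) and also a 24-fold lower number from compound 1 to compound 4 (1.39 log units; beyond the scatter) and a 13-fold lower number from compound 2 to compound 4 (1.11 log units; beyond the scatter) when set against the other two side chains. Going by these compounds alone, the steps among compound 1, compound 2 and compound 3 gave no sign that a change at this place could move the number so far, and all three of those compounds carry a carbonyl that compound 4 lacks. Nothing measured here gives a reason for this gain.

From the compounds shown here alone, compound 4 differs from the others in both the missing carbonyl and the size of its side chain, so the share of each in the gain remains open. A longer chain on the same oxygen, or an amine in place of that oxygen, would help to pull the two apart.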